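Methoxy for Hydrogen: Extending Compound 3 to Compound 4

A few compounds are considered here, and "the series" means these few. Any claim that something is new, unique, unknown or untested is made for them only; others in the source may bear on it.

Of the compounds shown here, three sharing one core have been measured in a functional assay on NCI-H1975 cells (Homo sapiens) for antiproliferative activity, read by MTT assay, with a stated time of 72 h; a higher number here means a weaker inhibitor, a lower number a stronger inhibitor. Compound 1 `COc1cc2ncnc(Nc3cccc(Br)c3)c2cc1OCCCCC(=O)Nc1ccc(S(N)(=O)=O)cc1` gives 11400 nM in this assay. Compound 2 `COc1cc2ncnc(Nc3cccc(Cl)c3)c2cc1OCCCCC(=O)Nc1ccc(S(N)(=O)=O)cc1` gives 33200 nM, and the step of a 2.9-fold higher number from compound 1 to compound 2 (0.46 log units; beyond the scatter). Compound 3 `COc1ccc(Nc2ncnc3cc(OC)c(OCCCCC(=O)Nc4ccc(S(N)(=O)=O)cc4)cc23)cc1` gives 30200 nM; the step of a 2.6-fold higher number from compound 1 to compound 3 (0.42 log units; beyond the scatter), while the step of a 1.1-fold lower number from compound 2 to compound 3 (0.04 log units; within the scatter). On these numbers compound 3 stands second highest of the three, indistinguishable from compound 2 within the scatter and separated from compound 1 by a modest, real gap.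

Compound 4 `COc1ccc(Nc2ncnc3cc(OC)c(OCCCCC(=O)Nc4ccc(S(N)(=O)=O)cc4)cc23)cc1OC` differs from compound 3 in one place: methoxy in place of hydrogen on an aromatic carbon. Within the data shown here, no measured step adds a group of this kind to this ring; the steps that touch this ring at all, from compound 1 to compound 3 and from compound 2 to compound 3, exchange whole substituent patterns and are modest or within the scatter. Among the measured compounds shown here, the measured set therefore gives no direct precedent, and the account expects a step of a 1.1-fold lower number from compound 3 to compound 4 (0.03 log units; within the scatter) that stays near or within the scatter. For compound 4 the estimate in this assay is 28000 nM, expected to fall between 9000 nM and 85000 nM.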

Compound 4, half-maximal inhibitory concentration: 9230 nM
The estimate for compound 4 lay 3.0-fold (0.48 log units) above the measured number; the range from low to high includes it.
By their numbers in this assay, from the lowest: compounds 4 and 1 (each within the scatter of the next); then compounds 3 and 2 (each within the scatter of the next).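

In this assay, among these compounds, the change from 4-methoxyphenyl to 3,4-dimethoxyphenyl brings a 3.3-fold lower number from compound 3 to compound 4 (0.51 log units; beyond the scatter), which shows that this ring responds to a single added methoxy on an aromatic carbon, ortho to a methoxy group and meta to a large group, whereas the earlier steps on this ring only exchanged whole substituent patterns. The 3,4-dimethoxyphenyl group also separates from 3-chlorophenyl, with a 3.6-fold lower number from compound 2 to compound 4 (0.56 log units; beyond the scatter), while its comparison with 3-bromophenyl gives a 1.2-fold lower number from compound 1 to compound 4 (0.09 log units; within the scatter), so the added methoxy brings the series level with the bromo compound and the two cannot be told apart in this assay. Nothing given here bears on why this methoxy group has this effect on the cells.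

The compounds shown leave open whether the step depends on the methoxy group already on the ring, or whether a 3-methoxyphenyl group alone would give the same result. They also leave open whether a hydroxy group, an ethoxy group or an amine on the same aromatic carbon would behave as the methoxy group does, and whether the step would hold with a longer chain linking the core to the sulfonamide-bearing ring.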